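This account rests on a few compounds, and the source may have more. Where it says the series, first, only, none or still open, it means among the compounds named here.

Measured in an ADME assay on HepG2 cells (Homo sapiens) for cytotoxicity, read by resazurin assay, with a stated time of 48 h; on this read-out lower numbers stand for an effect already at smaller amounts and higher numbers for an effect only at larger amounts of compound:
Compound 1 `O=C(Nc1ccc(F)c(-c2nc3ncc(-c4ccc(F)nc4)cc3[nH]2)c1)N1CCCC1`: > 50000 nM (a limit)
Compound 2 `O=C(Nc1ccc(F)c(-c2nc3ncc(-c4cc(F)cc(F)c4)cc3[nH]2)c1)N1CCCC1`: > 50000 nM (a limit)

For the measured compounds named here, compound 2 has no number on this read-out, only a limit, and the one other compound measured also gives only a limit. The evidence so far amounts to the limit of > 50000 nM in this assay, at which 2 of the 2 values shown sit. Going by the values given here, the single measured step is a step that the two limits leave unreadable from compound 1 to compound 2, and it places 3,5-difluorophenyl where 6-fluoropyridin-3-yl stood on an aromatic carbon.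

Compound 3 `O=C(Nc1ccc(F)c(-c2nc3ncc(-c4ccccc4F)cc3[nH]2)c1)N1CCCC1` changes the same aromatic carbon again, with 2-fluorophenyl in place of 3,5-difluorophenyl on an aromatic carbon. Among the compounds with values here, both groups are fluorinated carbon-only aromatic rings, and the two measured compounds offer no step of readable size to scale from. No step beyond the usual scatter is therefore expected in this assay, and no direction can be given. The most likely outcome is that compound 3 is also reported only as a limit.

Compound 3 is estimated at 50000 nM, with an expected range from 25000 nM to 100000 nM. The expected change is a number no higher from compound 2 to compound 3 (the limit leaves the size open).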

Compound 3, half-maximal effective concentration: > 50000 nM
Compound 3: a limit, no number (the forecaster's own chance of this, stated with the estimate: 85%); the middle value sits exactly at the limit.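

In this assay compound 3 gives > 50000 nM, which is a limit and not a number. For the compounds shown here, no step among compound 1, compound 2 and compound 3 can therefore be read. The compounds shown leave open whether the groups on that aromatic carbon differ at all on this read-out, since the data stop at one value: the limit of > 50000 nM in this assay, at which 3 of the 3 values shown sit.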